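A few compounds are considered here, and "the series" means these few. Any claim that something is new, unique, unknown or untested is made for them only; others in the source may bear on it.

Measured so far in a functional assay on A549 cells (Homo sapiens) for cytotoxicity, read by MTT assay, with a stated time of 24 h, tested at 20 uM; a lower number here means a stronger effect, a higher number a weaker effect of the compound at the concentration tested:

compound 1, `CCCCCCCCCCOC(=O)CCC(=O)N1CCN(CCCOc2cc3c(Nc4ccc(F)c(Cl)c4)ncnc3cc2OC)CC1`: 88.2%
compound 2, `CCCCCCCCCCCCCCCOC(=O)CCC(=O)N1CCN(CCCOc2cc3c(Nc4ccc(F)c(Cl)c4)ncnc3cc2OC)CC1`: 91.2%
compound 3, `CCCCCCCCCCCCCCCCCOC(=O)CCC(=O)N1CCN(CCCOc2cc3c(Nc4ccc(F)c(Cl)c4)ncnc3cc2OC)CC1`: 97.2%

All three share one core and differ only in the length of the saturated chain on the ester side. Compound 3 carries the highest of the three numbers, though its separation from the others is small: the step of a number 6 percentage points higher from compound 2 to compound 3 (within the scatter) and the step of a number 9 percentage points higher from compound 1 to compound 3 (within the scatter) both sit inside the usual scatter, so no ordering among the three can be claimed. The remaining pair, a number 3 percentage points higher from compound 1 to compound 2 (within the scatter), tells the same story.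

Compound 4, `CCCCCCCCCCCCCCCCCCOC(=O)CCC(=O)N1CCN(CCCOc2cc3c(Nc4ccc(F)c(Cl)c4)ncnc3cc2OC)CC1`, is the next member of this chain-lengthening sequence. Relative to compound 3 the change is methyl in place of hydrogen on a saturated chain carbon, ten or more bonds along the chain from an oxygen next to a carbonyl group.

The three measured steps all concern the same kind of lengthening on the same saturated chain, and none of them moved this assay beyond the scatter. The step from compound 3 to compound 4 is the smallest lengthening of the set, so the expectation is that it too produces no change beyond the scatter; the expected step is a number 0.3 percentage points higher from compound 3 to compound 4 (within the scatter). Compound 4 is accordingly estimated at 97.5%, with a range from 88% to 105%.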

Compound 4, a percentage reported as activity, at one concentration (the size of the read-out at that concentration, not a potency): 90.5%
Estimate against measurement, compound 4: 7 percentage points above; the measured number falls inside the stated range.
By their numbers in this assay, from the lowest: compounds 1, 4, 2 and 3 (each within the scatter of the next).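

Working notes on the ester-side chain, read in this assay: methyl in place of hydrogen gives the first step in this series with a lower number on lengthening (a number 6.7 percentage points lower from compound 3 to compound 4 (within the scatter)), and the propyl step gives a lower number too (a number 0.7 percentage points lower from compound 2 to compound 4 (within the scatter)), while the octyl step gives a higher one (a number 2.3 percentage points higher from compound 1 to compound 4 (within the scatter)). All three new steps lie within the scatter, so across the four compounds this position shows no dependence on chain length that can be read, and the first three numbers cannot be taken as the start of a trend, with compound 4 at 90.5% giving that idea no support. Nothing available bears on why these chain changes leave the read-out within the scatter.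

From the compounds shown here alone, whether a much shorter chain such as butyl, or a terminal amine or carboxylic acid on the chain, would move this read-out beyond the scatter stays open. Also open, going by these compounds, is whether an amide in place of the ester linkage would leave the number where these four compounds sit.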